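Methoxy for Trifluoromethyl on an Unmeasured Aryl Piperazine

The compounds below may be only part of what the source reports. "The series", "measured", "known", "first", "only" and "open" are said of these compounds alone.

Three compounds share one core, differing only in the group on the aryl ring. In an ADME assay on MCF7 cells (Homo sapiens) for cytotoxicity, read by MTT assay, with a stated time of 48 h (on this read-out lower numbers stand for stronger inhibition and higher numbers for weaker inhibition), compound 1 `Fc1ccc(N2CCN(Cn3nc(-c4ccncc4)oc3=S)CC2)cc1` reaches only a limit of the assay, > 250000 nM. Compound 2 `S=c1oc(-c2ccncc2)nn1CN1CCN(c2cccc(Cl)c2)CC1` has no result in this assay, "not determined" (no result reported). Compound 3 `FC(F)(F)c1ccccc1N1CCN(Cn2nc(-c3ccncc3)oc2=S)CC1`, carrying trifluoromethyl, likewise stands without a number, "not determined" (no result reported). For the measured compounds named here, the value of compound 1 is a limit of the assay and the entry for compound 2 is empty, so no measured step can be counted at all. Compound 4 `COc1ccccc1N1CCN(Cn2nc(-c3ccncc3)oc2=S)CC1` differs from compound 3 by methoxy in place of trifluoromethyl on an aromatic carbon. With no numbers to anchor a step, no shift beyond the scatter is expected in this assay in either direction. Compound 4 is therefore expected at 200000 nM, within 50000 nM to 400000 nM, and may well return only a limit.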

Compound 4, half-maximal inhibitory concentration: > 250000 nM
Compound 4: a limit, no number (the forecaster's own chance of this, stated with the estimate: 60%); middle value at least 1.2-fold (0.09 log units) away from the limit.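

Compound 1 and compound 4 each give only a limit of the assay, so no step between them can be read: the limit of > 250000 nM in this assay, at which 2 of the 4 values shown sit.

The compounds shown leave open whether methoxy in place of trifluoromethyl changes the read-out, and whether any of these compounds gives an actual number.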